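The compounds below may be only part of what the source reports. "The series", "measured", "known", "first", "only" and "open" are said of these compounds alone.

Three thiourea compounds built on the same core were tested in an ADME assay on isolated protein for inhibition of peroxidase (Raphanus sativus), read by fluorescence and Amplex Red, tested at 5 uM; a higher number here means a weaker effect of the compound at the concentration tested, a lower number a stronger effect. Compound 1 `Oc1ccccc1NC(=S)Nc1ccc2[nH]ccc2c1` gives 43.9%, compound 2 `Oc1cccc(NC(=S)Nc2ccc3[nH]ccc3c2)c1` gives 81.4%, and compound 3 `COc1ccc(NC(=S)Nc2ccc3[nH]ccc3c2)cc1` gives 67.6%. Among these three numbers compound 3 stands second highest: its nearest neighbour is compound 2, whose number lies higher by a margin beyond the usual scatter, and its furthest is compound 1, whose number lies lower, again beyond the scatter. Compound 4 `O=C(c1ccccc1)c1ccc(NC(=S)Nc2ccc3[nH]ccc3c2)cc1` has not yet been measured in this assay. It differs from compound 3 in one place: benzoyl in place of methoxy on an aromatic carbon. Among the compounds with values here, no pair of measured compounds differing in a single place is available, so the measured numbers give no direct reading of what a benzoyl in place of a methoxy does in this assay. The step from compound 3 to compound 4 in this assay is therefore expected to be modest, probably downward toward a somewhat stronger effect, and it may well stay within the scatter. Compound 4 is expected to come out at 60%, with a range from 40% to 80%. The expected step is a number 7.6 percentage points lower from compound 3 to compound 4 (within the scatter).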

Compound 4, a percentage reported as activity, at one concentration (the size of the read-out at that concentration, not a potency): 79.1%
Beside the measured number, compound 4's estimate is 19.1 percentage points below it; the measured number falls inside the stated range.
By their numbers in this assay, from the lowest: compound 1; then compound 3; then compounds 4 and 2 (each within the scatter of the next).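

In this assay, within the data shown here, replacing methoxy with benzoyl on the aromatic carbon para to a large group gives a number 11.5 percentage points higher from compound 3 to compound 4 (beyond the scatter), the first change at a single place that can be read here, and it shows that the read-out responds to what stands at this position. The entering benzoyl brings eight heavy atoms and an aromatic ring in place of the two heavy atoms and no ring of methoxy, with one hydrogen-bond acceptor on each side, and this exchange goes with a weaker effect at the concentration tested. No measurement at hand accounts for this step.

One pair cannot show whether the weaker effect follows the size of the group at this position or belongs to benzoyl in particular, and it sets no trend for other groups. As far as these compounds go, how an amine, a carboxylic acid or a longer chain on this same carbon would read remains open, as does whether the same exchange would give a step of this size on a different aromatic carbon.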